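The source may report more compounds than this note shows. Statements on the series, on what has been measured and on what is new or still open speak of the compounds shown alone.

Measured in an ADME assay on microsomes from liver (Homo sapiens) for metabolic stability, read by LC-MS, using NADPH, with stated times of 5 min and 30 min, tested at 1 uM; on this read-out lower numbers stand for slow clearance and higher numbers for fast clearance:
Compound 1 `O=C1c2ccccc2CN1c1cnc(NCc2c(F)ccc3c2CCO3)n2cnnc12`: 13 mL.min-1.g-1
Compound 2 `CC(=O)N1CCC(c2cnc(NCc3c(F)ccc4c3CCO4)c3cn[nH]c(=O)c23)CC1`: 207 mL.min-1.g-1
Compound 3 `C[C@H]1CC(=O)N(c2cnc(NCc3c(F)ccc4c3CCO4)n3cnnc23)C1`: < 3 mL.min-1.g-1 (a limit of the assay, not a number)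

Of the two actual numbers, compound 2 holds the higher, 207 mL.min-1.g-1, well beyond the scatter from compound 1, which gives 13 mL.min-1.g-1.

Compound 4 `CNC(=O)c1ccc(-c2cnc(NCc3c(F)ccc4c3CCO4)c3cn[nH]c(=O)c23)c(C)n1` keeps the core of compound 2 and changes one group: 2-methyl-6-(methylcarbamoyl)pyridin-3-yl in place of 1-acetylpiperidin-4-yl on an aromatic carbon. In words, this puts 2-methyl-6-(methylcarbamoyl)pyridin-3-yl in place of 1-acetylpiperidin-4-yl on an aromatic carbon.

Going by the values given here, only one measured step bears on this, and only loosely, as it sits on another core: an at least 4.3-fold lower number from compound 1 to compound 3 (0.63 log units; beyond the scatter). There a six-membered aromatic ring left and the number fell, whereas here an aromatic ring enters, which hints at a rise. Yet with compound 2 already at 207 mL.min-1.g-1, a moderate fall in this assay seems likelier, though the direction remains uncertain. The estimated change is a 3.5-fold lower number from compound 2 to compound 4 (0.54 log units; beyond the scatter). For compound 4 the expected value is 60 mL.min-1.g-1, with an estimated range of 15 mL.min-1.g-1 to 230 mL.min-1.g-1.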

Compound 4, intrinsic clearance in microsomes: 23 mL.min-1.g-1
The estimate for compound 4 lay 2.6-fold (0.42 log units) above the measured number; the measured number falls inside the stated range.
By their numbers in this assay, from the lowest: compounds 1 and 4 (each within the scatter of the next); then compound 2. At a limit, below all of these: compound 3.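

In this assay, replacing 1-acetylpiperidin-4-yl with 2-methyl-6-(methylcarbamoyl)pyridin-3-yl on this aromatic carbon gives a 9.0-fold lower number from compound 2 to compound 4 (0.95 log units; beyond the scatter), so the group held at this position strongly affects the read-out on this core. On another core, the number fell from compound 1 to compound 3 as an aromatic ring left, whereas here it falls as an aromatic ring enters, so these two steps give no single rule about aromatic rings. Nothing measured here accounts for the fall seen with compound 4.

The new group differs from the old one in its ring, its methyl and its methylcarbamoyl all at once, and the compounds shown do not tell which of these parts matters. A plain pyridin-3-yl, a pyridine bearing a carboxylic acid in place of the methylcarbamoyl, or a piperidin-4-yl with a free amine would help separate them.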